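Pyrrole ester series: amide-to-methyl-ester step at compound 2

The source may report more compounds than this note shows. Statements on the series, on what has been measured and on what is new or still open speak of the compounds shown alone.

Three compounds of the shared core have numbers in an assay on CHO cells for inhibition of metabotropic glutamate receptor 1 (Rattus norvegicus) (on this read-out higher numbers stand for weaker inhibition and lower numbers for stronger inhibition), so far. Compound 1 `Cc1c(C(=O)OC(C)C(C)(C)C)c[nH]c1C(=O)OC(C)CN(C)C` gives 390 nM; compound 3 `Cc1c(C(=O)OC(C)C(C)(C)C)c[nH]c1C(=O)Oc1cccnc1` gives 720 nM; compound 2 `CCCOC(=O)c1[nH]c(C(=O)NCC2CC2)c(C(=O)OC(C)(C)C)c1C` gives 2500 nM, the highest of the three, separated from compound 3 by a gap beyond the scatter and from compound 1 by a larger one. Within the data shown here, compound 2 also carries a (cyclopropylmethyl)carbamoyl group where compound 1 and compound 3 carry esters, alongside further differences, so no single step connects it to either.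

Compound 4 `CCCOC(=O)c1[nH]c(C(=O)OC)c(C(=O)OC(C)(C)C)c1C` is reached from compound 2 by methoxy in place of (cyclopropylmethyl)amino on a carbonyl carbon. Among the measured compounds shown here, the only measured step, a 1.8-fold higher number from compound 1 to compound 3 (0.27 log units; within the scatter), concerns the ester oxygen group at a different place and does not bear on an amide-to-ester exchange; no measured pair isolates that change. The comparison therefore rests on the observation that compound 1 and compound 3, both diesters, sit well below compound 2, which is the sole amide.

Taking that as a loose guide, compound 4 is expected to move toward the diester range, with an estimated step of a 2.5-fold lower number from compound 2 to compound 4 (0.40 log units; beyond the scatter). The expected value for compound 4 in this assay is 1000 nM, within an estimated range of 350 nM to 3000 nM.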

Compound 4, half-maximal inhibitory concentration: 3200 nM
Estimate against measurement, compound 4: 3.2-fold (0.51 log units) below; the whole stated range lies below it.
By their numbers in this assay, from the lowest: compounds 1 and 3 (each within the scatter of the next); then compounds 2 and 4 (each within the scatter of the next).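

In this assay methoxy in place of (cyclopropylmethyl)amino on a carbonyl carbon gives a 1.3-fold higher number from compound 2 to compound 4 (0.11 log units; within the scatter) and so leaves compound 2 and compound 4 indistinguishable, even though the exchange removes both the three-membered ring and the hydrogen-bond donor of the amide. At this place, therefore, the read-out does not register the loss of these two features taken together, although the pair cannot show what either does alone. The amide alone also no longer marks out the higher numbers: compound 4 carries an ester here yet groups with compound 2, not with compound 1 and compound 3, and what separates those groups remains unassigned, as they differ in more than one place; no measurement at hand explains the result.

Still open, as far as these compounds go, is whether a carboxylic acid, a primary amide or a dimethylamino-bearing chain on this carbonyl carbon would depart from the level shared by compound 2 and compound 4. Also open, from the compounds shown here alone, is whether the flat step holds on the core of compound 1, which has a different set of ester groups.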